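Piperidine amide variation: oxetanylamine to methyl-oxadiazolyl piperazine

The source may report more compounds than this note shows. Statements on the series, on what has been measured and on what is new or still open speak of the compounds shown alone.

Measured so far:
Compound 1 `CCN(CC)S(=O)(=O)c1ccc(S(=O)(=O)N2CCC[C@@H](C(=O)N3CCN(c4nc(C(F)(F)F)no4)CC3)C2)cc1`: 600 nM in a functional assay on MIA PaCa-2 cells (Homo sapiens) for inhibition, read by MTT assay, with a stated time of 7 days; a higher number here means a weaker inhibitor, a lower number a stronger inhibitor
Compound 2 `CCN(CC)S(=O)(=O)c1ccc(S(=O)(=O)N2CCC[C@@H](C(=O)NC3COC3)C2)cc1`: 2300 nM in this assay

Compound 2 stands at the higher of the two numbers, with compound 1 a clearly stronger inhibitor by a gap beyond the usual scatter. The next compound, compound 3 `CCN(CC)S(=O)(=O)c1ccc(S(=O)(=O)N2CCC[C@@H](C(=O)N3CCN(c4nc(C)no4)CC3)C2)cc1`, arises from compound 2 by the change (4-(3-methyl-1,2,4-oxadiazol-5-yl)piperazin-1-yl in place of (oxetan-3-yl)amino on a carbonyl carbon). Among the compounds with values here, no measured pair shows this exact step, so its size can only be judged from what the two values show. Since compound 1, which carries a piperazine-linked oxadiazole rather than an oxetanylamide, gives 600 nM, compound 3 is expected to move in the direction of stronger inhibition, with the step of a 2.6-fold lower number from compound 2 to compound 3 (0.41 log units; beyond the scatter) estimated to lie beyond the scatter. For compound 3 the expected value in this assay is 900 nM, with a likely range from 400 nM to 2500 nM.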

Compound 3, half-maximal inhibitory concentration: 250 nM
Compound 3: the middle estimate sits 3.6-fold (0.56 log units) above what was measured, and the stated range ends above it.
By their numbers in this assay, from the lowest: compound 3; then compound 1; then compound 2.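

In this assay, within the data shown here, 4-(3-methyl-1,2,4-oxadiazol-5-yl)piperazin-1-yl in place of (oxetan-3-yl)amino on the carbonyl carbon gives a 9.2-fold lower number from compound 2 to compound 3 (0.96 log units; beyond the scatter), the first direct reading of this change at this position. Methyl in place of trifluoromethyl on the aromatic carbon gives a 2.4-fold lower number from compound 1 to compound 3 (0.38 log units; beyond the scatter), which shows that the group on that carbon also shifts the number and that trifluoromethyl is not required for the lowest value among these compounds. Nothing available accounts for either step.

On these data alone, it remains open how much of the first step belongs to the piperazine and how much to the oxadiazole, which an acetyl group in place of the oxadiazole could help to separate. Also open, as far as these compounds go, is how an ethyl or cyclopropyl group in place of methyl on that aromatic carbon would read.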